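The compounds below may be only part of what the source reports. "The series", "measured", "known", "first", "only" and "open" are said of these compounds alone.

Compound 2 `CCC(C)C(C#CC(=O)OC)O/C=C/C(=O)OC` gives 340 nM; compound 1 `COC(=O)C#CC(O/C=C/C(=O)OC)C(C)c1ccccc1` gives 490 nM; compound 3 `C#CC(O/C=C/C(=O)OC)c1ccccc1` gives 26000 nM.

In a functional assay on HBL-100 cells (Homo sapiens) for antiproliferative activity, read by sulforhodamine B assay, with a stated time of 48 h (a lower number here means a stronger inhibitor of growth, a higher number a weaker inhibitor of growth), compound 2 holds the lowest of the three numbers. Its nearest neighbour is compound 1, whose value lies within the scatter of it, while compound 3 sits far higher. Compound 4 `COC(=O)C#CC(C)O/C=C/C(=O)OC` has not yet been measured. It differs from compound 2 in one place: methyl in place of sec-butyl on a saturated chain carbon bound to an oxygen on an unsaturated carbon and a triple-bonded carbon.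

Among the measured compounds shown here, one measured step bears on this question, a 1.4-fold lower number from compound 1 to compound 2 (0.16 log units; within the scatter), which is within the scatter and shows that one swap at the chain end of compound 2 passes without visible effect. That step alters a different carbon, though. For the measured compounds named here, no measured pair shows what happens when the sec-butyl is replaced by methyl. Going by the values given here, the large gap between compound 2 and compound 3 shows that other changes can cost a great deal, but no single-place step links those two compounds.

Pending the measurement, compound 4 is expected to give 1500 nM, with a range from 400 nM to 6000 nM. This corresponds to an expected 4.4-fold higher number from compound 2 to compound 4 (0.64 log units; beyond the scatter), a loss that would go beyond the scatter, though a smaller step cannot be ruled out.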

Compound 4, concentration for 50% growth inhibition: 300 nM
Beside the measured number, compound 4's estimate is 5.0-fold (0.70 log units) above it; the whole stated range lies above it.
By their numbers in this assay, from the lowest: compounds 4, 2 and 1 (each within the scatter of the next); then compound 3.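

In this assay, among the compounds shown here, the step of a 1.1-fold lower number from compound 2 to compound 4 (0.05 log units; within the scatter) is the first direct reading of this position, the saturated chain carbon bound to an oxygen on an unsaturated carbon and a triple-bonded carbon. The earlier step altered a different carbon, so it could say nothing about this place; now sec-butyl and methyl have been compared here, and the exchange leaves the growth-inhibition number within the scatter. At this level of activity, then, the sec-butyl group as a whole can give way to methyl with no measurable effect in this assay, although this rests on a single pair of compounds, and nothing shown here explains the result.

Going by these compounds, it remains open whether other groups at this position would behave in the same way, for instance an amine, a carboxylic acid or a chain longer than sec-butyl. For the compounds shown here, the high value of compound 3 at 26000 nM also stays unassigned, as compound 3 differs from compound 4 in more than one place and no single-place step connects them.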